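The source may hold more compounds than are shown below. What is called first, only, known or untested is meant among the compounds shown, and "the series" means these compounds.

Of the compounds shown here, three sharing one core have been tested in a functional assay on SK-MEL-28 cells (Homo sapiens) for inhibition; on this read-out lower numbers stand for stronger inhibition and higher numbers for weaker inhibition. Compound 1 `COc1ccc(/C=C/c2ccc3ccccc3c2)cc1` gives > 5000 nM, which is a limit and not a number. Compound 2 `COc1ccc(/C=C/c2ccc3ccccc3c2)cc1F`, with a fluoro added on an aromatic carbon, gives > 5000 nM, again a limit. Compound 3 `COc1ccc(/C=C/c2ccc3ccccc3c2)cc1[N+](=O)[O-]`, with a nitro there instead, gives > 5000 nM, also a limit. So compound 3 stands where the others do, at the limit of > 5000 nM in this assay, at which 3 of the 3 values shown sit.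

Compound 4 `CCN(CC)c1cc(/C=C/c2ccc3ccccc3c2)ccc1OC` carries diethylamino in place of nitro on an aromatic carbon, ortho to a methoxy group (diethylamino in place of nitro on an aromatic carbon). Going by the values given here, the steps that bear on this change are a step that the two limits leave unreadable from compound 1 to compound 3 and a step that the two limits leave unreadable from compound 2 to compound 3. Among the compounds with values here, neither has a size that can be read, and no tested compound carries diethylamino. The expectation therefore rests on compound 3 at > 5000 nM, and no clear gain in inhibition is expected. The estimated change is a step that the limit leaves unreadable from compound 3 to compound 4. Compound 4 is expected near 7000 nM, with an estimated range from 2500 nM to 20000 nM.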

Compound 4, half-maximal inhibitory concentration: > 5000 nM
Compound 4: a limit, no number (the forecaster's own chance of this, stated with the estimate: 80%); the middle value is on the limit's open side.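

Compound 4 gives a limit and not a number, like compound 1, compound 2 and compound 3, so no step among these compounds can be read: the limit of > 5000 nM in this assay, at which 4 of the 4 values shown sit. Left open is whether any of these groups changes inhibition in this assay at all, and by how much.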